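Methoxy to hydroxy on compound 2: working notes

The compounds below may be only part of what the source reports. "The series", "measured", "known", "first", "only" and "open" are said of these compounds alone.

In an ADME assay for permeability, using PAMPA, with a stated time of 10 h, tested at 100 ug/mL (on this read-out lower numbers stand for lower permeability and higher numbers for higher permeability), two compounds have been read so far. Compound 1 `Oc1ccc2[nH]c(-c3ccc4cccc(O)c4n3)cc2c1` gives 14.8 10^-6 cm/s as its value, and compound 2 `COc1cc2cc(-c3ccc4c(Cl)cc(Cl)c(O)c4n3)[nH]c2cc1OC` gives 3.9 10^-6 cm/s as its value. Compound 2 therefore stands lower of the two numbers, by more than the usual scatter. For the measured compounds named here, these two compounds differ in more than one place, so no measured single-place step is available as a guide.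

Next comes compound 3 `COc1cc2[nH]c(-c3ccc4c(Cl)cc(Cl)c(O)c4n3)cc2cc1O`, which is one change away from compound 2. The change is hydrogen in place of methyl on an oxygen on an aromatic ring and reads as hydrogen in place of methyl on an oxygen on an aromatic ring, or methoxy to hydroxy.

The anchor for the expectation is compound 2 at 3.9 10^-6 cm/s as measured. The expectation in this assay is no step beyond the scatter, with only a slight lean downward, and the estimated size is a 1.1-fold lower number from compound 2 to compound 3 (0.05 log units; within the scatter) as a working figure. For compound 3 the expected value is 3.5 10^-6 cm/s within an estimated range of 1.5 10^-6 cm/s to 8 10^-6 cm/s overall.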

Compound 3, apparent permeability: 8.4 10^-6 cm/s
The estimate for compound 3 lay 2.4-fold (0.38 log units) below the measured number; the measured number lies above the stated range.
By their numbers in this assay, from the lowest: compound 2; then compounds 3 and 1 (each within the scatter of the next).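

The series now has its first measured single-place step: in this assay, methoxy to hydroxy on an oxygen on an aromatic ring gives a 2.2-fold higher number from compound 2 to compound 3 (0.33 log units; beyond the scatter). At this place, then, hydrogen in place of methyl goes with a higher number, not with a number held within the scatter; the step is modest, and it rests on this one pair, with the second methoxy and both chlorines of compound 2 kept in compound 3. Nothing available here bears on why the number moves in this direction.

Still open, from the compounds shown here alone, is whether the same change would give a step of similar size and direction at the remaining methoxy of compound 3, or on a core carrying other groups, since one pair sets no pattern for the series. Also open, going by these compounds, is how the number would respond to something other than hydrogen or methyl on this oxygen, such as an ethyl or a longer chain ending in an amine or a carboxylic acid.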